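Growing the Amide Nitrogen Substituent: Compound 2 to Compound 3

A few compounds are considered here, and "the series" means these few. Any claim that something is new, unique, unknown or untested is made for them only; others in the source may bear on it.

Two compounds have so far been measured in an assay on HEK293 cells for inhibition of transient receptor potential cation channel subfamily M member 8 (Homo sapiens), read by FLIPR and calcium flux; on this read-out higher numbers stand for weaker inhibition and lower numbers for stronger inhibition:

Compound 1, `CN(C(=O)c1ccccc1OCc1ccccc1)[C@@H]1CCC[C@H](N)C1`: 3670 nM
Compound 2, `CC(C)N(C(=O)c1ccccc1OCc1ccccc1)[C@@H]1CCC[C@H](N)C1`: 5130 nM

The two share a core and differ only at the amide-type nitrogen, where compound 1 carries a methyl and compound 2 an isopropyl. Of the two numbers in this assay, compound 2 holds the higher one, but its nearest neighbour is compound 1 and the gap between them stays within the scatter: a 1.4-fold higher number from compound 1 to compound 2 (0.15 log units; within the scatter). Compound 3, `N[C@H]1CCC[C@@H](N(CC2CC2)C(=O)c2ccccc2OCc2ccccc2)C1`, takes the same position one step further: cyclopropylmethyl in place of isopropyl on an amide-type nitrogen. For the measured compounds named here, the only measured step that bears on this change is the one between compound 1 and compound 2, which enlarged the group on the same nitrogen without moving the number beyond the scatter. With nothing else to go on, no step beyond the scatter is expected in this assay for compound 3 either. Compound 3 is therefore estimated at about 5000 nM in this assay, with a range from 2000 nM to 13000 nM. The step this estimate implies, a 1.0-fold lower number from compound 2 to compound 3 (0.01 log units; within the scatter), is expected to stay within the scatter.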

Compound 3, antagonist equilibrium constant: 665 nM
Beside the measured number, compound 3's estimate is 7.5-fold (0.88 log units) above it, and the stated range ends above it.
By their numbers in this assay, from the lowest: compound 3; then compounds 1 and 2 (each within the scatter of the next).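

In this assay the amide-type nitrogen proves sensitive to the group it carries, which the methyl and isopropyl pair had not shown: cyclopropylmethyl brings a 7.7-fold lower number from compound 2 to compound 3 (0.89 log units; beyond the scatter) and also a 5.5-fold lower number from compound 1 to compound 3 (0.74 log units; beyond the scatter). Both steps lie beyond the scatter, so the number at this position does not simply follow enlargement of the group: isopropyl stays within the scatter of methyl, while cyclopropylmethyl, with 4 heavy atoms and a three-membered ring, separates from both. Nothing available here accounts for why this group stands apart from the other two.

Compound 3 is the only compound shown with a ring on this nitrogen, so the ring and the added carbon cannot be told apart: an open n-butyl chain with the same carbon count would separate the two, and a cyclobutylmethyl group would show whether a larger ring on the same carbon keeps the lower number. The compounds shown also leave open whether a hydroxyethyl or methoxyethyl chain on this nitrogen would fit the same picture, and whether the step holds once the benzyl group of the shared core is replaced.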